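A few compounds are considered here, and "the series" means these few. Any claim that something is new, unique, unknown or untested is made for them only; others in the source may bear on it.

In a functional assay on MDA-MB-231 cells (Homo sapiens) for cytotoxicity, read by MTT assay, with a stated time of 72 h (a lower number here means a stronger inhibitor, a higher number a weaker inhibitor), compound 1 `CN1CCN(c2ccc(NC(=N)c3cc4cn[nH]c4cn3)cc2)CC1` gives 47500 nM. Compound 2 `CN1CCN(c2ccc(NC(=N)c3cc4cn(C)nc4cn3)cc2)CC1` gives 20500 nM in this assay, the lowest of the two numbers, with compound 1 the nearest at a higher number, beyond the scatter. The difference between the two cores is not broken down here. For compound 3 `N=C(Nc1ccccc1)c1cc2cn[nH]c2cn1`, this assay reports only a limit, > 50000 nM. This is the limit of > 50000 nM in this assay, at which 1 of the 3 values shown sits. The change hydrogen in place of 4-methylpiperazin-1-yl on an aromatic carbon thus gave an at least 1.0-fold higher number from compound 1 to compound 3 (0.02 log units; that floor lies within the scatter). Compound 4 `Cn1cc2cc(C(=N)Nc3ccccc3)ncc2n1` carries the same change relative to compound 2, (hydrogen in place of 4-methylpiperazin-1-yl on an aromatic carbon), at a place described in the same words. A step of similar direction is expected here, a 2.0-fold higher number from compound 2 to compound 4 (0.29 log units; within the scatter), resting on an at least 1.0-fold higher number from compound 1 to compound 3 (0.02 log units; that floor lies within the scatter). Compound 4 is therefore estimated at 40000 nM, expected to lie between 18000 nM and 90000 nM.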

Compound 4, half-maximal inhibitory concentration: > 50000 nM
Compound 4: no number, only a limit; the forecaster's own chance of this, stated with the estimate: 35%; middle value at least 1.2-fold (0.09 log units) from the limit.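

In this assay compound 4 gives only a limit, > 50000 nM. Hydrogen in place of 4-methylpiperazin-1-yl on an aromatic carbon gave an at least 2.4-fold higher number from compound 2 to compound 4 (0.38 log units; beyond the scatter), so on this core the change moves the number beyond the scatter, though its full size is not shown. It cannot be said whether the change acts alike or differently on the two cores: the same change on two cores in this assay, an at least 1.0-fold higher number (0.02 log units; that floor lies within the scatter) from compound 1 to compound 3 and an at least 2.4-fold higher number (0.38 log units; beyond the scatter) from compound 2 to compound 4; the limit leaves it open whether they differ

Going by these compounds, how far compound 3 and compound 4 lie past that limit stays open: the limit of > 50000 nM in this assay, at which 2 of the 4 values shown sit. Also open is what a morpholine or a dimethylamino group would give in place of 4-methylpiperazin-1-yl.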